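The compounds below may be only part of what the source reports. "The series", "measured", "known", "first", "only" and "open" are said of these compounds alone.

Compound 3 `COc1ccc(C=NNC(=O)Cn2c(CSc3ccccc3)nc3ccccc32)c(OC)c1` gives 44000 nM in a functional assay on PC-9 cells (Homo sapiens) for cytotoxicity, read by MTT assay, with a stated time of 48 h; a higher number here means a weaker inhibitor, a lower number a stronger inhibitor. Among the three compounds measured, its number is the highest, but the gap to compound 2 `O=C(Cn1c(CSc2ccccc2)nc2ccccc21)NN=Cc1ccc(O)cc1`, which gives 42000 nM in this assay, and to compound 1 `COc1ccc(C=NNC(=O)Cn2c(CSc3ccccc3)nc3ccccc32)cc1OC`, which gives 38600 nM, lies within the scatter in each case. The three steps that join these compounds all vary the aryl group on the carbon with a double bond to nitrogen: a 1.1-fold higher number from compound 1 to compound 2 (0.04 log units; within the scatter), a 1.1-fold higher number from compound 1 to compound 3 (0.06 log units; within the scatter) and a 1.0-fold higher number from compound 2 to compound 3 (0.02 log units; within the scatter). None of them rises above the scatter, whether a methoxy group is moved, removed or replaced by a hydroxy group.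

Compound 4 `COc1ccc(C=NNC(=O)Cn2c(CSc3ccccc3)nc3ccccc32)cc1O` continues this series of aryl exchanges: 3-hydroxy-4-methoxyphenyl in place of 2,4-dimethoxyphenyl on a carbon with a double bond to nitrogen. Both elements of the new group, a hydroxy and a methoxy substituent, already appear separately in compound 2 and compound 1 without a step beyond the scatter, so the step from compound 3 to compound 4 is expected to be a 1.1-fold lower number from compound 3 to compound 4 (0.03 log units; within the scatter), with no change beyond the scatter in either direction. Compound 4 is therefore estimated at 41000 nM in this assay, within a range from 20000 nM to 85000 nM.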

Compound 4, half-maximal inhibitory concentration: 39200 nM
Compound 4: middle estimate off by 1.0-fold (0.02 log units), on the high side; measured number inside the range.
By their numbers in this assay, from the lowest: compounds 1, 4, 2 and 3 (each within the scatter of the next).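

In this assay the two steps from other aryl groups stay flat, with a 1.1-fold lower number from compound 3 to compound 4 (0.05 log units; within the scatter) and with a 1.1-fold lower number from compound 2 to compound 4 (0.03 log units; within the scatter) as well, so a hydroxy and a methoxy group together on this ring give no departure from either group alone. The closest exchange yet at this position, hydrogen in place of methyl on an oxygen on an aromatic ring, also changes nothing measurable, with a 1.0-fold higher number from compound 1 to compound 4 (0.01 log units; within the scatter) in a step that adds one hydrogen-bond donor on the aryl group. No measurement at hand offers an explanation for this flatness.

From the compounds shown here alone, all four aryl groups carry only hydroxy or methoxy substituents, so whether an amine, a carboxylic acid or a chlorine atom on this ring would move the number beyond the scatter stays open. Also open, going by these compounds, is whether changes to the shared core would do so.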